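Nitro to Carboxy: Expecting the Activity of Compound 3

The source may report more compounds than this note shows. Statements on the series, on what has been measured and on what is new or still open speak of the compounds shown alone.

Of the compounds shown here, two built on a shared core have so far been tested in a functional assay on MCF7 cells (Homo sapiens) for antiproliferative activity, read by MTT assay, with a stated time of 48 h; on this read-out lower numbers stand for stronger inhibition and higher numbers for weaker inhibition. Compound 1 `O=C1C=CC2(C=C1)OC(=O)C(c1ccc([N+](=O)[O-])cc1)=C2c1ccccc1` carries a 4-nitrophenyl group, and in this assay compound 1 gives 5990 nM. Within the data shown here, compound 2 `COc1cc(C2=C(c3ccccc3)C3(C=CC(=O)C=C3)OC2=O)cc(OC)c1OC` is the only other measured compound; in this assay compound 2 gives 5790 nM. Compound 1 thus holds the higher of the two numbers, yet the gap to compound 2 lies within the scatter, so the two compounds cannot be distinguished on these data. Compound 2 differs from compound 1 in more than one place, so no single structural change can be read from that pair.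

Compound 3 `O=C1C=CC2(C=C1)OC(=O)C(c1ccc(C(=O)O)cc1)=C2c1ccccc1` differs from compound 1 in exactly one place: carboxy in place of nitro on an aromatic carbon. Among the measured compounds shown here, no measured pair shows this change, so no measured step guides the forecast. In the absence of such a pair, the expectation is a step of no more than the scatter, in either direction, and the step from compound 1 to compound 3 is estimated as a 1.1-fold higher number from compound 1 to compound 3 (0.04 log units; within the scatter). Compound 3 is therefore expected to give about 6500 nM in this assay, within a range from 2500 nM to 17000 nM.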

Compound 3, half-maximal inhibitory concentration: 5950 nM
For compound 3 the middle estimate is 1.1-fold (0.04 log units) above the measured one, and the stated range covers the measured number.
By their numbers in this assay, from the lowest: compounds 2, 3 and 1 (each within the scatter of the next).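

Among these compounds, putting carboxy in place of nitro on this aromatic carbon gives a 1.0-fold lower number from compound 1 to compound 3 (0.00 log units; within the scatter) in this assay, the first reading of a single change on the shared core. The two groups differ in their counts, since carboxy brings one hydrogen-bond donor where nitro has none and one hydrogen-bond acceptor where nitro has two, yet compound 1 and compound 3 cannot be told apart on this read-out, so at this position, para to a large group, that particular swap leaves the antiproliferative number within the scatter. No separate measurement is at hand to explain why the number stays put, so the result stands as an observation only.

One pair at one position cannot show whether this spot tolerates substitution in general, so an amine, a methoxy group or a longer alkyl chain in the same place might read differently or might not. From the compounds shown here alone, whether carboxy and nitro would also match on a core with a different group on the other aromatic ring, such as the phenyl group of compound 1, remains open as well.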